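The source may hold more compounds than are shown below. What is called first, only, known or untested is meant among the compounds shown, and "the series" means these compounds.

Among the measured compounds shown here, only two compounds sharing this core have been measured so far. In a functional assay on MCF7 cells (Homo sapiens) for cytotoxicity, read by MTT assay, with a stated time of 96 h (on this read-out higher numbers stand for weaker inhibition and lower numbers for stronger inhibition), compound 1 (`COc1cc(C(=O)c2cn(-c3ccc(F)cc3)cc2-c2ccc(N)cc2)cc(OC)c1OC`) gives 12 nM as the lower number. Compound 2 (`COc1cc(C(=O)c2cn(-c3ccc(N)cc3)cc2-c2cccc(N)c2)cc(OC)c1OC`) gives 78 nM and so stands highest of the two, making it the weaker inhibitor of the pair by a gap beyond the usual scatter.

Compound 3 (`COc1cc(C(=O)c2cn(-c3ccc(N)cc3)cc2-c2ccc(N)cc2)cc(OC)c1OC`) has the same atoms as compound 2, joined differently (4-aminophenyl in place of 3-aminophenyl on an aromatic carbon): 4-aminophenyl in place of 3-aminophenyl on an aromatic carbon. For the measured compounds named here, no measured pair shows what this swap does on its own, so any expectation here is indirect. Compound 1 also carries a 4-aminophenyl group on that carbon and reaches 12 nM in this assay so a lower number is expected for compound 3. Compound 1 is not an exact match for compound 3, so only part of the gap is expected to close. The expected change is a fall beyond the scatter, estimated as a 3.1-fold lower number from compound 2 to compound 3 (0.49 log units; beyond the scatter) and pointing to stronger inhibition. In this assay compound 3 is estimated at 25 nM with an expected range from 7 nM to 80 nM for repeat measurements.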

Compound 3, half-maximal inhibitory concentration: 15 nM
The estimate for compound 3 lay 1.7-fold (0.22 log units) above the measured number; the range from low to high includes it.
By their numbers in this assay, from the lowest: compounds 1 and 3 (each within the scatter of the next); then compound 2.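

Moving the amino group from the 3-aminophenyl to the 4-aminophenyl arrangement, with nothing else altered, gives a 5.2-fold lower number from compound 2 to compound 3 (0.72 log units; beyond the scatter) in this assay, so this place on the shared core distinguishes between two groups built from the same atoms. The other comparison concerns a different place: amino in place of fluoro on an aromatic carbon gives a 1.3-fold higher number from compound 1 to compound 3 (0.10 log units; within the scatter), so this swap produces no difference that can be told apart from ordinary repeat variation. No measurement offered here explains why the 4-aminophenyl and 3-aminophenyl groups differ.

The compounds shown leave open whether the amino group itself is needed in the 4-aminophenyl group, since a 4-hydroxyphenyl or 4-methoxyphenyl group in that place could show whether other groups serve equally well, and a 2-aminophenyl group would complete the set of amino arrangements. For the amino and fluoro swap, chloro or methyl on the same aromatic carbon would test whether the tolerance seen in this single pair extends beyond these two groups.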